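A few compounds are considered here, and "the series" means these few. Any claim that something is new, unique, unknown or untested is made for them only; others in the source may bear on it.

Working notes on the series, read in a functional assay, read by spectrophotometry; on this read-out lower numbers stand for stronger inhibition and higher numbers for weaker inhibition. Compound 1 `COC(=O)c1cc(-c2csc(N/N=C/c3cccs3)n2)ccc1OCc1ccccc1` gives 29.2 ug/mL, compound 2 `Clc1ccc(-c2csc(N/N=C/c3cccs3)n2)cc1` gives 39.6 ug/mL and compound 3 `Fc1ccc(-c2csc(N/N=C/c3ccc(Cl)cc3Cl)n2)cc1` gives 35.5 ug/mL. These three numbers lie within the scatter of one another, so compound 3 stands level with both other compounds and the set shows no separation. Compound 4 `Clc1ccc(/C=N/Nc2nc(-c3ccccc3)cs2)c(Cl)c1` differs from compound 3 by a single change: hydrogen in place of fluoro on an aromatic carbon. Among the compounds with values here, no measured pair shows this change, so the data offer no direct guide to its size, and no shift beyond the scatter is expected. The estimated step, a 1.0-fold higher number from compound 3 to compound 4 (0.02 log units; within the scatter), is small and has no firm direction. Compound 4 is estimated at 37 ug/mL, with an expected range of 20 ug/mL to 65 ug/mL.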

Compound 4, half-maximal inhibitory concentration: 43.7 ug/mL
Beside the measured number, compound 4's estimate is 1.2-fold (0.07 log units) below it; the measured number falls inside the stated range.
By their numbers in this assay, from the lowest: compounds 1, 3, 2 and 4 (each within the scatter of the next).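

Within the data shown here, the change from 4-fluorophenyl to phenyl gives a 1.2-fold higher number from compound 3 to compound 4 (0.09 log units; within the scatter) and is the first pair that differs in one place. It puts a measured size on this change: on an aromatic carbon para to a large group, hydrogen and fluoro stand level in this read-out. No measurement shown offers an explanation for this result.

As far as these compounds go, the change is read on the background of compound 3 alone, so its size on the other compounds stays open. From the compounds shown here alone, whether an amine or a carboxylic acid at this place would give a step beyond the scatter also stays open.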